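The compounds below may be only part of what the source reports. "The series", "measured", "known", "first", "only" and "open" are said of these compounds alone.

Compound 1 `Cc1cc(Cl)ccc1OCc1nnc(-c2cccc(F)c2)o1` was examined in an ADME assay on cells for inhibition of anoctamin-2 (Homo sapiens), read by fluorescence, with a stated time of 20 min; on this read-out lower numbers stand for stronger inhibition and higher numbers for weaker inhibition. In this assay compound 1 gives > 100000 nM, which is a limit of the measurement and not a number; it sits at the limit of > 100000 nM in this assay, at which 1 of the 2 values shown sits. A close relative, compound 2 `Cc1cc(Cl)ccc1OCc1nnc(-c2cccc(OC(F)(F)F)c2)o1`, is recorded in this assay as "not active" (no number reported). Compound 3 `Cc1cc(Cl)ccc1OCc1nnc(-c2ccccn2)o1` carries pyridin-2-yl in place of 3-fluorophenyl on an aromatic carbon. Going by the values given here, no measured pair shows how such a change acts here, so the expected step is a number no higher from compound 1 to compound 3 (the limit leaves the size open), none beyond the scatter. Compound 3 is therefore estimated at 100000 nM, within 30000 nM to 300000 nM, most likely again only a limit.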

Compound 3, half-maximal inhibitory concentration: "not active" (no number reported)
No number was reported for compound 3; no gap can be computed for the estimate.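

No step can be read from compound 1 to compound 3, since compound 1 gives only a limit and compound 3 has no number. The compounds shown leave open whether swapping 3-fluorophenyl for pyridin-2-yl changes inhibition in this assay at all.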